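Working notes: hydroxy loss from compound 3

A few compounds are considered here, and "the series" means these few. Any claim that something is new, unique, unknown or untested is made for them only; others in the source may bear on it.

Measured in an ADME assay on HUVEC cells (Homo sapiens) for cytotoxicity, read by MTT assay, with a stated time of 24 h; a lower number here means a stronger inhibitor, a higher number a weaker inhibitor:
- compound 1 `C[C@@H]1O[C@@]1(C)C(=O)C[C@H]1[C@](C)(O)CC[C@@]2(O)C(C)(C)CCC[C@]12C`: > 10000 nM
- compound 2 `C[C@H]1O[C@]1(C)C(=O)C[C@H]1[C@](C)(O)CC[C@@]2(O)C(C)(C)CCC[C@]12C`: > 10000 nM
- compound 3 `C/C=C(\C)C(=O)C[C@@H]1[C@@]2(C)[C@@H](O)CCC(C)(C)[C@]2(O)CC[C@@]1(C)O`: > 10000 nM

Each of these three entries is a limit of the assay and not a number. For compound 3 the entry > 10000 nM is such a limit, so its position in this assay is known only as a limit.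

The next compound is compound 4 `C/C=C(\C)C(=O)C[C@H]1[C@](C)(O)CC[C@@]2(O)C(C)(C)CCC[C@]12C`, which carries hydrogen in place of hydroxy on a saturated ring carbon.

Going by the values given here, only one measured step is available, and it bears on this change only loosely: a step that the two limits leave unreadable from compound 1 to compound 2. That pair offers (the fact that compounds 1 and 2 differ only in the configuration as drawn), not an exchange of groups, so it supplies no size to carry over. Among the compounds with values here, no measured step covers the loss of a hydroxy group. The remaining evidence is the limit of > 10000 nM in this assay, at which 3 of the 3 values shown sit.

On that basis, compound 4 is expected to read as a limit again, with no step beyond the scatter in either direction. The expected step is a step that the limit leaves unreadable from compound 3 to compound 4, an estimate with no direction supported by the data. For compound 4 the estimated value is 15000 nM, with an expected range from 7000 nM to 40000 nM.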

Compound 4, half-maximal inhibitory concentration: > 10000 nM
Compound 4: no number, only a limit; the forecaster's own chance of this, stated with the estimate: 85%; the middle value does not contradict the limit.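

In this assay compound 4 gives > 10000 nM, a limit of the assay and not a number, and its steps from compound 1, compound 2 and compound 3 cannot be read. The compounds shown leave open whether the hydroxy group, the 2,3-dimethyloxiran-2-yl group or the configuration as drawn has any bearing on this assay, as every entry is a limit: the limit of > 10000 nM in this assay, at which 4 of the 4 values shown sit.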